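This account rests on a few compounds, and the source may have more. Where it says the series, first, only, none or still open, it means among the compounds named here.

Measured compounds:
- compound 1, `COc1ccc(-c2cn3ccnc3c(-c3ccc4ncn(C5CCCCC5)c4c3)n2)cc1`, 95.2%
- compound 2, `COc1ccccc1-c1cn2ccnc2c(-c2ccc3ncn(C4CCCCC4)c3c2)n1`, 43.1%
- compound 3, `CCc1ccc(-c2cn3ccnc3c(-c3ccc4ncn(Cc5ccccc5)c4c3)n2)cc1`, 50.4%

In a functional assay on PC-3 cells (Homo sapiens) for inhibition, read by sulforhodamine B assay, with a stated time of 48 h, tested at 10 uM (a higher number here means more inhibition at the concentration tested (going by the name of the read-out), a lower number less inhibition), the three compounds spread widely. Compound 1 gives the highest number of the three. Compound 3 stands second highest: its nearest neighbour is compound 2, whose number is lower by a margin that lies within the scatter, so no order between compound 2 and compound 3 can be claimed; its furthest neighbour is compound 1, whose number is higher by a margin beyond the scatter. Going by the values given here, the one step that can be read from the measured pairs is a number 52.1 percentage points lower from compound 1 to compound 2 (beyond the scatter), a large fall for a change of position of the methoxy group; it does not touch the group that changes next.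

Compound 4, `O=Cc1ccc(-c2cn3ccnc3c(-c3ccc4ncn(Cc5ccccc5)c4c3)n2)cc1`, differs from compound 3 by formyl in place of ethyl on an aromatic carbon. Among the compounds with values here, no measured pair shows this exchange, and the step from compound 1 to compound 2 concerns a different ring and a different group, so it gives no guide to direction. With nothing to lean on, the expected step is a number 5.4 percentage points lower from compound 3 to compound 4 (within the scatter), which is small relative to the scatter. The estimate for compound 4 in this assay is therefore 45%, expected to fall between 20% and 75%.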

Compound 4, a percentage reported as inhibition, at one concentration (the size of the read-out at that concentration, not a potency): 19%
Estimate against measurement, compound 4: 26 percentage points above; the whole stated range lies above it.
By their numbers in this assay, from the lowest: compound 4; then compounds 2 and 3 (each within the scatter of the next); then compound 1.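

Going by these compounds alone, the earlier compounds showed only that moving a methoxy group around its ring can change the number; here the place stays fixed, on an aromatic carbon para to a large group, and exchanging the group itself gives a number 31.4 percentage points lower from compound 3 to compound 4 (beyond the scatter) in this assay. Ethyl and formyl have the same count of heavy atoms, so a large step at this place can occur without any change in that count; what differs is the oxygen, the double bond outside the aromatic ring and the hydrogen-bond acceptor that formyl brings. Which of these features goes with the step cannot be told from this single pair, and no measurement shown speaks to an explanation.

The compounds shown leave open how an amine, a carboxylic acid or a hydroxymethyl group would read at this place, and whether a plain phenyl ring with no group there would stand nearer to compound 3 or to compound 4. They also leave open whether the same exchange would give a step of similar size in the setting of compound 1, which differs from compound 3 in more than one place.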